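The source may report more compounds than this note shows. Statements on the series, on what has been measured and on what is new or still open speak of the compounds shown alone.

Compound 1 `O=C(NC(=S)Nc1ccc(Cl)c(-c2nc3ccccc3[nH]2)c1)c1ccc(OCc2ccc(C(F)(F)F)cc2)cc1` gives 12900 nM in a functional assay on HT-29 cells (Homo sapiens) for inhibition, read by MTT assay, with a stated time of 48 h; on this read-out lower numbers stand for stronger inhibition and higher numbers for weaker inhibition. Compound 2 `O=C(NC(=S)Nc1ccc(Cl)c(-c2nc3ccccc3[nH]2)c1)c1ccc(OCc2ccc(Cl)c(Cl)c2)cc1` carries a 3,4-dichlorophenyl group where compound 1 carries 4-(trifluoromethyl)phenyl; in this assay compound 2 gives 4930 nM, which is the lower of the two numbers, and the step of a 2.6-fold lower number from compound 1 to compound 2 (0.42 log units; beyond the scatter) lies beyond the scatter. Compound 3 `O=C(NC(=S)Nc1ccc(Cl)c(-c2nc3ccccc3[nH]2)c1)c1ccc(OCc2ccc(Cl)cc2Cl)cc1` differs from compound 2 only in the change (2,4-dichlorophenyl in place of 3,4-dichlorophenyl on a saturated chain carbon bound to an oxygen on an aromatic ring), so the same atoms are kept and only joined differently. Among the measured compounds shown here, no measured step moves substituents around within this ring while keeping the atoms the same; the one step known, a 2.6-fold lower number from compound 1 to compound 2 (0.42 log units; beyond the scatter), swaps the whole group and therefore gives little guidance here. For such a rearrangement the expected step, a 1.2-fold higher number from compound 2 to compound 3 (0.09 log units; within the scatter), falls within the scatter. Compound 3 is therefore expected to give about 6000 nM in this assay, with a range from 2500 nM to 15000 nM.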

Compound 3, half-maximal inhibitory concentration: 6080 nM
The estimate for compound 3 lay 1.0-fold (0.01 log units) below the measured number; low and high end bracket the measured number.
By their numbers in this assay, from the lowest: compounds 2 and 3 (each within the scatter of the next); then compound 1.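

Rearranging the same atoms, with 2,4-dichlorophenyl in place of 3,4-dichlorophenyl, gives no clear difference in this assay (a 1.2-fold higher number from compound 2 to compound 3 (0.09 log units; within the scatter)), so among these two compounds the placing of the two chlorines on this ring has little visible effect on the number. The other new step is a 2.1-fold lower number from compound 1 to compound 3 (0.33 log units; beyond the scatter), which means that compound 2 and compound 3 both stand apart from compound 1, and the gain seen earlier is not confined to a single dichlorophenyl arrangement. Nothing available gives a reason for either step.

As far as these compounds go, whether two chlorines are needed remains open, since a plain phenyl or a 4-chlorophenyl group at this position could give a similar number or a quite different one. From the compounds shown here alone, what a more different group would do there, such as a pyridine ring or a phenyl ring carrying a carboxylic acid, also stays unknown.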